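The source may hold more compounds than are shown below. What is called first, only, known or untested is meant among the compounds shown, and "the series" means these compounds.

Compound 1 `Oc1cccc(-c2cc(-c3ccc(Cl)cc3)nc(-c3ccccn3)c2)c1` and compound 2 `Oc1cccc(-c2cc(-c3ccccc3)nc(-c3ccc(Cl)cc3)c2)c1` share one core and were both tested in an ADME assay on HEK293 cells (Homo sapiens) for cytotoxicity, read by CCK-8 assay and cell counting, with a stated time of 2 days; a higher number here means a weaker inhibitor, a lower number a stronger inhibitor. In this assay compound 1 gives 14000 nM, and compound 2 gives 11600 nM. The change between them is phenyl in place of pyridin-2-yl on an aromatic carbon, and the step it made, a 1.2-fold lower number from compound 1 to compound 2 (0.08 log units; within the scatter), is within the scatter. Compound 3 `Oc1cccc(-c2cc(-c3ccccn3)nc(-c3ccccc3Cl)c2)c1` has no single number in this assay: in this assay compound 3 gives "not determined" (no result reported). Its core differs from that of compound 1 by 2-chlorophenyl in place of 4-chlorophenyl on an aromatic carbon. Compound 4 `Oc1cccc(-c2cc(-c3ccccc3)nc(-c3ccccc3Cl)c2)c1` is made from compound 3 by phenyl in place of pyridin-2-yl on an aromatic carbon; the change is the same kind of change as that from compound 1 to compound 2, but around the place it is meta to a 2-chlorophenyl group rather than meta to a 4-chlorophenyl group. Going by the values given here, since compound 3 lacks a value, no step can be given. For compound 4 a value of about 12000 nM is expected, most likely between 5000 nM and 30000 nM, because compound 1 gives 14000 nM and compound 2 gives 11600 nM and the change between them stayed within the scatter.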

Compound 4, half-maximal inhibitory concentration: 1760 nM
Compound 4: the middle estimate sits 6.8-fold (0.83 log units) above what was measured; measured number outside the range, below it.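

In this assay, 2-chlorophenyl in place of 4-chlorophenyl gives a 6.6-fold lower number from compound 2 to compound 4 (0.82 log units; beyond the scatter), so this change of chlorophenyl group matters when the neighbouring group on the shared core is phenyl. On these data alone, the step for phenyl in place of pyridin-2-yl was a 1.2-fold lower number from compound 1 to compound 2 (0.08 log units; within the scatter) with a 4-chlorophenyl group present, but it cannot be read with a 2-chlorophenyl group present, as compound 3 has no result, so whether it carries over to that core remains unknown. Nothing given here explains the size of the new step.

As far as these compounds go, it also remains open whether the step from compound 2 to compound 4 would recur with pyridin-2-yl in place of phenyl. From the compounds shown here alone, the effect of a 2-fluorophenyl group, or of an amine in place of the hydroxyl of the 3-hydroxyphenyl group, is equally open.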